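Methoxy for hydroxy on the shared core

The source may report more compounds than this note shows. Statements on the series, on what has been measured and on what is new or still open speak of the compounds shown alone.

Measured compounds:
compound 1 `O=C(Nc1cccc(-n2cc(-c3ccncc3)c(-c3cc(O)cc(Cl)c3)n2)c1)Nc1ccc(Cl)c(C(F)(F)F)c1` — -93%
compound 2 `O=C(Nc1cccc(-n2cc(-c3ccncc3)c(-c3cc(O)cc(Cl)c3)n2)c1)Nc1ccc(Cl)c(Cl)c1` — -38%

Within the data shown here, in a functional assay on BT-549 cells (Homo sapiens) for inhibition, read by sulforhodamine B assay, with a stated time of 48 h, tested at 100 uM (on this read-out higher numbers stand for a weaker effect at the one concentration tested and lower numbers for a stronger effect), compound 1 gives the lowest of the two numbers; compound 2 sits a number 55 percentage points higher from compound 1 to compound 2 (beyond the scatter) away, the only measured step in the set. Compound 3 `COc1cc(Cl)cc(-c2nn(-c3cccc(NC(=O)Nc4ccc(Cl)c(C(F)(F)F)c4)c3)cc2-c2ccncc2)c1` differs from compound 1 by methyl in place of hydrogen on an oxygen on an aromatic ring. Among the measured compounds shown here, no measured step touches this oxygen, so the change from chloro to trifluoromethyl says nothing direct about it. With nothing to anchor a shift, compound 3 is expected to lie close to compound 1, a step of a number 18 percentage points higher from compound 1 to compound 3 (beyond the scatter), with the range widened toward weaker effect. The estimate for compound 3 is -75%, between -100% and -30%.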

Compound 3, a percentage reported as activity, at one concentration (the size of the read-out at that concentration, not a potency): -68%
Estimate against measurement, compound 3: 7 percentage points below, within the range that was stated.
By their numbers in this assay, from the lowest: compound 1; then compound 3; then compound 2.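

In this assay, methoxy in place of hydroxy on the shared core gives a number 25 percentage points higher from compound 1 to compound 3 (beyond the scatter), a shift beyond the scatter. The free hydrogen on this oxygen therefore matters to the read-out, yet the effect does not depend on it entirely, as compound 3 still gives -68%. Nothing measured here accounts for the shift. Still open, from the compounds shown here alone, is how an amine or a longer chain such as ethoxy would read at this position. Also open, going by these compounds, is whether the same change gives a similar step on compound 2.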